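A few compounds are considered here, and "the series" means these few. Any claim that something is new, unique, unknown or untested is made for them only; others in the source may bear on it.

Three compounds of one family share a core in which a pyrazole bridge joins an aromatic ring to a chain ending in a carbonyl. Compound 1 `COc1ccc(-c2cc(/C=C/C(=O)c3ccc(OC)c(OC)c3)[nH]n2)cc1` and compound 2 `COc1ccc(-c2cc(/C=C/C(=O)c3ccc(N)cc3)[nH]n2)cc1` were joined by compound 3 `COc1ccc(C(=O)/C=C/c2cc(-c3cc(OC)c(OC)c(OC)c3)n[nH]2)cc1`. All three were tested in a functional assay on BT-549 cells (Homo sapiens) for cytotoxicity, read by sulforhodamine B assay, with a stated time of 48 h, tested at 10 uM; a higher number here means a weaker effect of the compound at the concentration tested, a lower number a stronger effect. Compound 1 gives -70%, compound 2 gives -37%, and compound 3 gives -65%. On these numbers compound 3 stands second highest of the three: its nearest neighbour is compound 1, a number within the scatter of it, and its furthest is compound 2, a number beyond the scatter above it.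

Among the compounds with values here, the next compound, compound 4 `COc1cc(-c2cc(/C=C/C(=O)c3ccc(F)c(F)c3)[nH]n2)cc(OC)c1OC`, keeps the core of compound 3 and changes only one ring: 3,4-difluorophenyl in place of 4-methoxyphenyl on a carbonyl carbon. Within the data shown here, no measured pair shows a change of this kind, so no step can be read from the data. The expectation is a small step, if any, in a number 10 percentage points higher from compound 3 to compound 4 (within the scatter), staying within the scatter. Compound 4 is therefore estimated at -55% in this assay, with a range from -85% to -20%.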

Compound 4, a percentage reported as activity, at one concentration (the size of the read-out at that concentration, not a potency): 23%
Estimate against measurement, compound 4: 78 percentage points below, and the stated range ends below it.
By their numbers in this assay, from the lowest: compounds 1 and 3 (each within the scatter of the next); then compound 2; then compound 4.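

In this assay, within the data shown here, 3,4-difluorophenyl in place of 4-methoxyphenyl on a carbonyl carbon gives a number 88 percentage points higher from compound 3 to compound 4 (beyond the scatter), the first single change that can be read directly in this family. The step shows that the ring at this place strongly shapes the read-out, even though the rest of compound 4 matches compound 3 and both rings have the same number of heavy atoms. Nothing available explains why the step is so large.

As far as these compounds go, it remains open whether the weaker effect follows from losing the methoxy group or from gaining the two fluorines. How this place would respond to a ring carrying a single fluorine, or to one carrying a carboxylic acid, also cannot be told from the compounds shown.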